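Working notes: 3-chlorophenyl in place of 4-chlorophenyl

A few compounds are considered here, and "the series" means these few. Any claim that something is new, unique, unknown or untested is made for them only; others in the source may bear on it.

Compound 1 `CC(C(=O)N1CCN(c2ccc(Cl)cc2)CC1)N1C(=O)CCC1=O` was run in a functional assay on the whole organism (strain Swiss) with Mus musculus as the target, in the maximal electroshock model, with a stated time of 2 h, at a dose of 300 mg/kg by the intraperitoneal route (a lower number here means a weaker effect, a higher number a stronger effect of the compound at the dose given), where compound 1 gives 0%. Compound 2 `CCC(C(=O)N1CCN(c2cccc(F)c2)CC1)N1C(=O)CCC1=O` gives 0% in the same test, and compound 3 `CC(C(=O)N1CCN(c2ccc(C(F)(F)F)cc2)CC1)N1C(=O)CCC1=O` gives 0%. Compound 1 therefore stands level with compounds 2 and 3 at the digits shown, its nearest neighbour being compound 2 and its furthest compound 3, both within the scatter. Among the measured compounds shown here, the only single-site step among the measured compounds, trifluoromethyl in place of chloro on an aromatic carbon, gives no change at the digits printed from compound 1 to compound 3 (within the scatter).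

Compound 4 `CC(C(=O)N1CCN(c2cccc(Cl)c2)CC1)N1C(=O)CCC1=O` has not been measured. It differs from compound 1 by 3-chlorophenyl in place of 4-chlorophenyl on an amine nitrogen in a ring. For the measured compounds named here, no measured step moves the chloro around the aromatic ring, so the bearing of this change is indirect: the one step that alters the aromatic substituent stays within the scatter, and every measured reading in this assay sits at the same level. On that basis no step beyond the scatter is expected in either direction. Compound 4 is therefore expected to give 0%, with a range from 0% to 10%, an estimated step of no change at the digits printed from compound 1 to compound 4 (within the scatter) that is expected to stay within the scatter.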

Compound 4, a percentage reported as activity, at one dose (the size of the read-out at that dose, not a potency): 50%
Compound 4: the middle estimate sits 50 percentage points below what was measured; measured number outside the range, above it.
By their numbers in this assay, from the lowest: compounds 1, 2 and 3 (each within the scatter of the next); then compound 4.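

In this assay, 3-chlorophenyl in place of 4-chlorophenyl gives a number 50 percentage points higher from compound 1 to compound 4 (beyond the scatter), so the read-out at this position depends on where the chloro stands on the aromatic ring, although the two compounds have the same atoms. The earlier change on this ring, trifluoromethyl in place of chloro, gave no change at the digits printed from compound 1 to compound 3 (within the scatter) and did not show this sensitivity. Nothing available bears on why moving the chloro has this effect.

On these data alone, it remains open whether the 3-position effect is specific to chloro or would also appear with methoxy or nitrile in its place. Also open, as far as these compounds go, is whether the step from 4-chlorophenyl to 3-chlorophenyl would hold at other doses and times, or with a longer chain in place of the methyl group on the shared core.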